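The compounds below may be only part of what the source reports. "The series", "measured", "known", "first", "only" and "open" are said of these compounds alone.

Compound 1 `CC(C)N(Cc1cccc(OCCCCCC(=O)O)c1)C(=O)c1ccc(-c2cccc(-c3ccccc3)c2)cc1` stops at a limit in an ADME assay on HEK293 cells (Homo sapiens) for cytotoxicity, read by CellTiter-Glo and resazurin assay, with a stated time of 72 h (a higher number here means that more compound is needed for the effect, a lower number that less compound is needed), giving > 26000 nM.
Compound 2 `COc1cc(OC)cc(-c2ccc(C(=O)N(Cc3cccc(OCCCCCC(=O)O)c3)C(C)C)cc2)c1` also reaches only a limit, > 26000 nM.
Compound 3 `CC(C)N(Cc1cccc(OCCCCCC(=O)O)c1)C(=O)c1ccc(-c2c[nH]c3ccccc23)cc1` likewise gives only a limit, > 26000 nM.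

Compound 3 therefore stands where every measured value sits, at the limit of > 26000 nM in this assay, at which 3 of the 3 values shown sit. The steps among the measured compounds tell nothing about size: a step that the two limits leave unreadable from compound 1 to compound 2, a step that the two limits leave unreadable from compound 1 to compound 3 and a step that the two limits leave unreadable from compound 2 to compound 3 are all unreadable because each end is a limit. Compound 4 `CC(C)N(Cc1cccc(OCCCCCC(=O)O)c1)C(=O)c1ccc(-c2cccc(Cl)c2)cc1` arises from compound 3 by the change (3-chlorophenyl in place of 1H-indol-3-yl on an aromatic carbon). Going by the values given here, no measured step bears on it with a readable size, so nothing beyond the scatter is expected; compound 4 is expected to remain at the limit as well, giving 26000 nM in this assay, within 13000 nM to 60000 nM, an expected step of a number no higher from compound 3 to compound 4 (the limit leaves the size open).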

Compound 4, half-maximal effective concentration: > 21900 nM
Compound 4: only a limit was reported; the forecaster's own chance of this, stated with the estimate: 85%; the middle value does not contradict the limit.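

Compound 4 gives only a limit in this assay, > 21900 nM, and the steps to it from compound 1, compound 2 and compound 3 cannot be read. The compounds shown leave open what concentration of any of them produces the effect, and whether these groups differ at all.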